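This account rests on a few compounds, and the source may have more. Where it says the series, first, only, none or still open, it means among the compounds named here.

Measured so far in a functional assay, with a stated time of 10 min; a lower number here means a stronger inhibitor, a higher number a weaker inhibitor:
compound 1, `CCOC(=O)c1cnn(-c2nc(-c3ccc(OC)cc3)c(C#N)c(=O)n2C)c1N`, gives 74 ug/mL.
compound 2, `CSc1nc(-c2ccco2)c(C#N)c(=O)n1C`, gives 79 ug/mL.
compound 3, `CSc1nc(-c2ccccc2O)c(C#N)c(=O)n1C`, gives 39 ug/mL.

Compound 1 stands second highest of the three numbers. Its nearest neighbour is compound 2, within the scatter. Compound 3 gives the lowest number, but its gap to compound 1 is also within the scatter, so no order can be read among the three. Compound 4, `CCOC(=O)c1cnn(-c2nc(-c3ccc(Cl)cc3)c(C#N)c(=O)n2C)c1N`, is not yet measured. It differs from compound 1 in one place: chloro in place of methoxy on an aromatic carbon, 4-methoxyphenyl becoming 4-chlorophenyl. Within the data shown here, no step between measured compounds bears on this change, and all three measured values sit within the scatter of one another. No step beyond the scatter is expected. Compound 4 is estimated at 70 ug/mL, with a range of 30 ug/mL to 160 ug/mL. The step of a 1.1-fold lower number from compound 1 to compound 4 (0.02 log units; within the scatter) is expected to be essentially flat.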

Compound 4, half-maximal inhibitory concentration: 94 ug/mL
Compound 4: the middle estimate sits 1.3-fold (0.13 log units) below what was measured; the measured number falls inside the stated range.
By their numbers in this assay, from the lowest: compounds 3, 1, 2 and 4 (each within the scatter of the next, the first and the last beyond it).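

In this assay, among these compounds, the change from 4-methoxyphenyl to 4-chlorophenyl gives a 1.3-fold higher number from compound 1 to compound 4 (0.10 log units; within the scatter), the first direct reading at this place on the six-membered aromatic ring. Chloro in place of methoxy therefore leaves the number flat on the core of compound 1, despite the loss of the one oxygen acceptor counted in methoxy. Nothing on hand explains this flat step.

Going by these compounds, whether an amine or a carboxylic acid at this place would give a step beyond the scatter remains open. So does whether a longer chain, such as butoxy, would do so.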